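The source may report more compounds than this note shows. Statements on the series, on what has been measured and on what is new or still open speak of the compounds shown alone.

Working notes on the series built on the shared core of compound 1 `O=C1O[C@H]([C@@H](O)Cn2cc(-c3ccc(Br)cc3)nn2)C(OCc2ccccc2)=C1OCc1ccccc1` and compound 2 `CCCCCc1ccc(-c2cn(C[C@H](O)[C@H]3OC(=O)C(OCc4ccccc4)=C3OCc3ccccc3)nn2)cc1`. In an ADME assay on HFF cells (Homo sapiens) for cytotoxicity, read by MTT assay, with a stated time of 72 h (a higher number here means a weaker inhibitor, a lower number a stronger inhibitor), compound 1 gives 5100 nM. For compound 2 the value is a limit of the assay, > 100000 nM. The step of an at least 19-fold higher number from compound 1 to compound 2 (1.29 log units; beyond the scatter) is therefore set by the limit of > 100000 nM in this assay, at which 1 of the 2 values shown sits, and compound 2 stands at the upper edge of the numbers seen so far, with no number of its own. Compound 3 `COc1ccccc1-c1cn(C[C@H](O)[C@H]2OC(=O)C(OCc3ccccc3)=C2OCc2ccccc2)nn1` has not yet been measured in this assay. It differs from compound 2 in one place: 2-methoxyphenyl in place of 4-pentylphenyl on an aromatic carbon. Going by the values given here, the only measured step that bears on this change is an at least 19-fold higher number from compound 1 to compound 2 (1.29 log units; beyond the scatter), which shows how far the pentyl moved the number when it replaced bromo; compound 3 gives up that pentyl, which points back towards the region where compound 1 sits. For compound 3 the expected step is an at least 5.0-fold lower number from compound 2 to compound 3 (0.69 log units; beyond the scatter), downward from the limit. For compound 3 the expected value in this assay is 20000 nM, with a range from 5000 nM to 100000 nM.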

Compound 3, half-maximal inhibitory concentration: 50 nM
For compound 3 the middle estimate is 400-fold (2.60 log units) above the measured one; measured number outside the range, below it.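

At this aromatic carbon of the five-membered aromatic ring with 3 nitrogen, the number in this assay is not confined to the span from compound 1 up to the limit, since 2-methoxyphenyl gives a 100-fold lower number from compound 1 to compound 3 (2.01 log units; beyond the scatter), whereas the earlier pair showed movement in the upward direction only. The aryl group at this one place therefore carries the series across the whole range seen so far, with compound 3 holding the lowest number of the three on the same shared core. The step of an at least 2000-fold lower number from compound 2 to compound 3 (3.30 log units; beyond the scatter) starts from a limit and not from a number, so its full size stays unknown: the limit of > 100000 nM in this assay, at which 1 of the 3 values shown sits.

The compounds shown leave open whether the low number of compound 3 belongs to the methoxy group itself or to where that group stands on the phenyl ring, as the change replaces the group and its place together. Also open, going by these compounds, is whether a hydroxyl, an amine or a longer ether chain in place of the methoxy group would keep the number near that of compound 3.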